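Swapping the oxazole ring for a pyrazole on a benzimidazole

The source may hold more compounds than are shown below. What is called first, only, known or untested is meant among the compounds shown, and "the series" means these compounds.

Compound 2 `Fc1ccc2nc(-c3cnco3)n(C3CC3)c2c1` carries a 1,3-oxazol-5-yl group on the shared core. In an assay on cells for inhibition of cytochrome P450 11B2, mitochondrial (Homo sapiens), read by HPLC, with a stated time of 90 min (on this read-out lower numbers stand for stronger inhibition and higher numbers for weaker inhibition), compound 2 reaches only the limit of the measurement, > 10000 nM, so no number is known for it (the limit of > 10000 nM in this assay, at which 1 of the 2 values shown sits). Compound 1 `Fc1ccc2nc(-n3ccnn3)n(C3CC3)c2c1` differs from compound 2 only in bearing a 1H-1,2,3-triazol-1-yl group. In this assay compound 1 gives 1060 nM. Among the compounds with values here, the one measured step shows an at least 9.4-fold higher number from compound 1 to compound 2 (0.97 log units; beyond the scatter), that is, the exchange of the triazolyl ring for the oxazolyl ring weakened inhibition markedly.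

Compound 3 `Fc1ccc2nc(-c3cn[nH]c3)n(C3CC3)c2c1` is not yet measured. It differs from compound 2 as follows: 1H-pyrazol-4-yl in place of 1,3-oxazol-5-yl on an aromatic carbon. Within the data shown here, only the step from compound 1 to compound 2 bears on this change, and it moved in one direction only when a nitrogen-rich five-membered ring was replaced. Since the change to compound 3 again introduces a five-membered ring with two nitrogen atoms, a return toward lower numbers is expected, though the size is uncertain. The expected step is an at least 3.3-fold lower number from compound 2 to compound 3 (0.52 log units; beyond the scatter). For compound 3 the estimate in this assay is 3000 nM, with a range from 600 nM to 15000 nM.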

Compound 3, half-maximal inhibitory concentration: 782 nM
Compound 3: the middle estimate sits 3.8-fold (0.58 log units) above what was measured; low and high end bracket the measured number.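

In this assay, 1H-pyrazol-4-yl in place of 1,3-oxazol-5-yl gives an at least 12-fold lower number from compound 2 to compound 3 (1.10 log units; beyond the scatter), even though both groups are five-membered aromatic rings with 2 hetero atoms and the same count of heavy atoms, so the ring's size and its number of hetero atoms do not settle the outcome at this position. Compound 2 stands at a limit of the assay and not at a number, so this step gives only the smallest possible size of the gap: the limit of > 10000 nM in this assay, at which 1 of the 3 values shown sits. The pyrazolyl and triazolyl rings, by contrast, cannot be told apart here, with a 1.4-fold lower number from compound 1 to compound 3 (0.13 log units; within the scatter), which leaves the 1,3-oxazol-5-yl group of compound 2 as the one that stands apart among these three.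

Three rings cannot show which feature of the ring matters, and a 1-methyl-1H-pyrazol-4-yl group would test whether the hydrogen on the pyrazole nitrogen takes part in the result. From the compounds shown here alone, it also remains open whether a five-membered ring is needed here at all, a question that a six-membered pyridin-3-yl ring, a nitrile or a primary amine at this position could answer.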